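The compounds below may be only part of what the source reports. "The series", "measured", "known", "first", "only" and "open" are said of these compounds alone.

In an ADME assay on microsomes from liver (Mus musculus) for metabolic stability, read by LC-MS (a higher number here means that the compound lasts longer, a lower number that the compound disappears faster), compound 2 `O=C(Nc1ccc(F)c(-c2nc3ncc(-c4cccnc4F)cc3[nH]2)c1)N1CCCC1` gives > 1.5 h, which is a limit of the assay and not a measured number. Compound 3 `Cc1nc(C)c(C(=O)Nc2ccc(F)c(-c3nc4ncc(-c5ccccc5Cl)cn4n3)c2)o1`, which has a different core, gives > 1.5 h, also a limit. Going by these compounds, these two results form (the limit of > 1.5 h in this assay, at which 2 of the 3 values shown sit), so the exact standing of compound 2 is unknown. Compound 1 `O=C(Nc1ccc(F)c(-c2nc3ncc(-c4ccc(F)c(F)c4)cc3[nH]2)c1)N1CCCC1` gives a measured half-life of 0.08 h.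

The next analogue is compound 4 `O=C(Nc1ccc(F)c(-c2nc3ncc(-c4cc(F)cc(F)c4)cc3[nH]2)c1)N1CCCC1`, which keeps the core of compound 2 and carries 3,5-difluorophenyl in place of 2-fluoropyridin-3-yl on an aromatic carbon. Compound 4 thus resembles compound 1, which carries 3,4-difluorophenyl at the same place, and differs from it only in where the two fluorines sit.

Within the data shown here, one measured step bears directly on this change: an at least 18-fold higher number from compound 1 to compound 2 (1.27 log units; beyond the scatter). It is a single step, and it involves a different difluorophenyl group, so it gives only an approximate guide. A large fall in half-life is nevertheless expected for compound 4, because an at least 18-fold higher number from compound 1 to compound 2 (1.27 log units; beyond the scatter) would be largely reversed. The expected change is an at least 12-fold lower number from compound 2 to compound 4 (1.09 log units; beyond the scatter). For compound 4 the estimated half-life is 0.12 h, with an expected range from 0.05 h to 0.5 h.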

Compound 4, half-life: 0.128 h
Compound 4: middle estimate off by 1.1-fold (0.03 log units), on the low side; the range from low to high includes it.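

In this assay, 3,5-difluorophenyl in place of 2-fluoropyridin-3-yl gives an at least 11-fold lower number from compound 2 to compound 4 (1.06 log units; beyond the scatter), so the large step first seen with 3,4-difluorophenyl also appears with a second difluorophenyl group on the shared core. Between the two difluorophenyl groups themselves, this assay shows a 1.6-fold higher number from compound 1 to compound 4 (0.20 log units; within the scatter), so these two placements of the fluorines cannot be told apart in this assay. Among compound 1, compound 2 and compound 4, which differ only at this place, the two difluorophenyl groups therefore give measured half-lives, whereas 2-fluoropyridin-3-yl gives a limit, and none of the three goes against this pattern.

Going by these compounds, compound 2 gives > 1.5 h, a limit and not a number, so the full size of each step involving it stays open: the limit of > 1.5 h in this assay, at which 2 of the 4 values shown sit. Also open, on these data alone, is whether the ring nitrogen, the fluorine of 2-fluoropyridin-3-yl or the two together go with the longer half-life, a question that a plain pyridin-3-yl or a 2-fluorophenyl group at this place would bear on.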